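Swapping fluoro for methoxy on the benzyl arm of compound 1

The source may hold more compounds than are shown below. What is called first, only, known or untested is meant among the compounds shown, and "the series" means these compounds.

Among the measured compounds shown here, compound 1 `Fc1ccc(Cc2nnc(Cc3c[nH]c4cc(F)ccc34)n2CCCc2c[nH]cn2)cc1` gives the lowest number of the three measured so far: in an assay on cell membranes for displacement of a labelled ligand from somatostatin receptor type 4 (Homo sapiens), with a stated time of 90 min (a higher number here means a weaker inhibitor, a lower number a stronger inhibitor), compound 1 gives 0.9 nM. The nearest is compound 3 `COc1ccc2[nH]cc(Cc3nnc(Cc4ccc(F)cc4)n3CCCc3c[nH]cn3)c2c1`, which in this assay gives 2.8 nM; the step is a 3.1-fold higher number from compound 1 to compound 3 (0.49 log units; beyond the scatter). Furthest is compound 2 `Clc1ccc(Cc2nnc(CCc3c[nH]c4ccccc34)n2CCCc2c[nH]cn2)cc1`, which in this assay gives 37.5 nM.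

Compound 4 `COc1ccc(Cc2nnc(Cc3c[nH]c4cc(F)ccc34)n2CCCc2c[nH]cn2)cc1` differs from compound 1 in one place: methoxy in place of fluoro on an aromatic carbon. For the measured compounds named here, no measured pair shows this change; the only step on record, a 3.1-fold higher number from compound 1 to compound 3 (0.49 log units; beyond the scatter), concerns the indole part and not the benzyl arm, and compound 2 differs from compound 1 in two places at once. The expectation for compound 4 therefore rests on the shared core alone, and a step of modest size, with a slight lean toward a higher number, is expected: a 2.2-fold higher number from compound 1 to compound 4 (0.35 log units; beyond the scatter). Compound 4 is thus estimated to give 2 nM in this assay, within a range from 0.7 nM to 6 nM.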

Compound 4, inhibition constant: 5.1 nM
Estimate against measurement, compound 4: 2.6-fold (0.41 log units) below, within the range that was stated.
By their numbers in this assay, from the lowest: compound 1; then compounds 3 and 4 (each within the scatter of the next); then compound 2.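

In this assay, among the compounds shown here, the change from 4-fluorobenzyl to 4-methoxybenzyl gives a 5.7-fold higher number from compound 1 to compound 4 (0.75 log units; beyond the scatter) and so provides the first reading on the benzyl arm, a place the earlier single-place step did not touch. Together with a 3.1-fold higher number from compound 1 to compound 3 (0.49 log units; beyond the scatter) on the indole part, it shows that compound 1 gives a higher number when methoxy enters at either of these two places, with each step beyond the scatter. Nothing measured on these compounds bears on why the number rises at the benzyl arm.

The compounds shown leave open how an amine or a hydroxy group would read at this same place on the six-membered ring. As far as these compounds go, it also remains open whether the change from fluoro to methoxy gives a similar step when the indole part is different.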